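The source may hold more compounds than are shown below. What is called first, only, known or untested is meant among the compounds shown, and "the series" means these compounds.

Compounds measured so far:
compound 1 `NC(c1ccccc1)c1ccc(-c2ncnc3[nH]cnc23)cc1` with 400 nM
compound 2 `NC(c1ccc(Cl)cc1)c1ccc(-c2ncnc3[nH]cnc23)cc1` with 9 nM

Going by the values given here, in an assay on isolated protein for inhibition of RAC-beta serine/threonine-protein kinase (Homo sapiens), read by radiometric assay and filter binding (a higher number here means a weaker inhibitor, a lower number a stronger inhibitor), compound 2 gives the lower of the two numbers; the single step recorded, a 44-fold lower number from compound 1 to compound 2 (1.65 log units; beyond the scatter), separates it from compound 1. Compound 3 `CNC(c1ccc(Cl)cc1)c1ccc(-c2ncnc3[nH]cnc23)cc1` differs from compound 2 by methyl in place of hydrogen on an amine nitrogen. Among the compounds with values here, no measured step touches the amine nitrogen, so the recorded step offers no direct guide to this change. With the substitution at a different place, a modest change is expected, a 2.8-fold higher number from compound 2 to compound 3 (0.44 log units; beyond the scatter), as compound 3 is estimated at 25 nM, in the range 6 nM to 120 nM.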

Compound 3, half-maximal inhibitory concentration: 10 nM
Estimate against measurement, compound 3: 2.5-fold (0.40 log units) above; measured number inside the range.
By their numbers in this assay, from the lowest: compounds 2 and 3 (each within the scatter of the next); then compound 1.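

In this assay, methyl in place of hydrogen on the amine nitrogen gives a 1.1-fold higher number from compound 2 to compound 3 (0.05 log units; within the scatter), which lies within the scatter. Going by these compounds alone, this is the first reading at this position, and it shows that the amine nitrogen can carry a methyl with the number unchanged within the scatter, while the chloro remains in place. The compounds shown leave open whether a longer chain such as ethyl, a ring such as cyclopropyl or an acetyl on this nitrogen would be accepted equally. They also leave open how methyl on this nitrogen would read without the chloro. No supporting measurement bears on this result.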